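The compounds below may be only part of what the source reports. "The series", "measured", "known", "first", "only" and "open" are said of these compounds alone.

Measured compounds in the series so far:

Compound 1 `CC1CCN(C(=O)CN(C)C(=O)c2ccc(S(C)(=O)=O)c([N+](=O)[O-])c2)CC1` — in an assay on isolated protein for inhibition of thyroid hormone receptor alpha (Homo sapiens), read by fluorescence polarization (a lower number here means a stronger inhibitor, a higher number a weaker inhibitor), compound 1 gives > 60000 nM, a limit of the assay rather than a number.
Compound 2 `Cc1ccc(N2CCN(C(=O)C3CCN(C(=O)c4ccc(S(C)(=O)=O)c([N+](=O)[O-])c4)CC3)CC2)cc1` — in this assay compound 2 gives > 60000 nM, again a limit.
Compound 3 `CS(=O)(=O)c1ccc(C(=O)NCCCC(=O)N2Cc3ccccc3C2)cc1[N+](=O)[O-]` — in this assay compound 3 gives > 60000 nM, again a limit.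

Compound 2 therefore stands nowhere in particular on the numbers shown: its value in this assay is a limit, and the two other values shown are limits as well, so no order among the three can be read. The only common point is the limit of > 60000 nM in this assay, at which 3 of the 3 values shown sit, which every measured compound shares.

Compound 4 `CS(=O)(=O)c1ccc(C(=O)N2CCC(C(=O)N3CCN(c4ccc(F)cc4)CC3)CC2)cc1[N+](=O)[O-]` is not yet measured. Its difference from compound 2 is fluoro in place of methyl on an aromatic carbon.

For the measured compounds named here, no step between measured compounds exists, so there is no measured change to lean on. Given that compound 2 sits at a limit in this assay, the step from compound 2 to compound 4 is expected to be none beyond the scatter, and the value of compound 4 is most likely to come back as a limit too. The step that the limit leaves unreadable from compound 2 to compound 4 is the expected outcome. For compound 4 the estimate in this assay is 80000 nM, with a range from 20000 nM to 300000 nM.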

Compound 4, half-maximal inhibitory concentration: > 60000 nM
Compound 4 gave a limit, no number; the forecaster's own chance of this, stated with the estimate: 85%; the middle value does not contradict the limit.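

No step can be read between compound 2 and compound 4, as both results are limits and not numbers; the series has one common point: the limit of > 60000 nM in this assay, at which 4 of the 4 values shown sit.

The compounds shown leave open which structures, if any, give a numerical value in this assay, and what fluoro in place of methyl does where a value can be read.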